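Catechol ether in place of benzyl ether on the thiophene sulfonamide

The source may report more compounds than this note shows. Statements on the series, on what has been measured and on what is new or still open speak of the compounds shown alone.

Measured compounds:
compound 1, `O=S(=O)(NCCNC(=S)Nc1cc(C(F)(F)F)cc(C(F)(F)F)c1)c1ccc(-c2ccccc2OCc2ccccc2)s1`, 4700 nM in a functional assay on HeLa cells (Homo sapiens) for inhibition, read by CCK-8 assay, with a stated time of 48 h; on this read-out lower numbers stand for stronger inhibition and higher numbers for weaker inhibition
compound 2, `Cc1ccc(-c2ccsc2S(=O)(=O)NCCNC(=S)Nc2cc(C(F)(F)F)cc(C(F)(F)F)c2)c(Oc2ccc(O)c(O)c2)c1`, 8000 nM in this assay
compound 3, `CC(C)c1ccc(Oc2ccc(O)c(O)c2)c(-c2ccsc2S(=O)(=O)NCCNC(=S)Nc2cc(C(F)(F)F)cc(C(F)(F)F)c2)c1`, with a limit of > 20000 nM in this assay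

Compound 1 and compound 2 sit within the scatter of each other in this assay, so neither can be set apart from the other. Compound 3 reaches only a limit in this assay, and that limit is shared by the limit of > 20000 nM in this assay, at which 1 of the 3 values shown sits. Going by the values given here, no step between compounds that differ in one place is available here, so the comparison rests on single values.

Compound 4, `O=S(=O)(NCCNC(=S)Nc1cc(C(F)(F)F)cc(C(F)(F)F)c1)c1ccc(-c2ccccc2Oc2ccc(O)c(O)c2)s1`, has not yet been measured in this assay. It differs from compound 1 in one place: 3,4-dihydroxyphenyl in place of benzyl on an oxygen on an aromatic ring. Compound 2 and compound 3, which both carry a 3,4-dihydroxyphenoxy group, give no value stronger than compound 1, so a small weakening, of a size near the edge of the scatter, is expected from compound 1 to compound 4, a 1.7-fold higher number from compound 1 to compound 4 (0.23 log units; within the scatter). Compound 4 is therefore estimated at 8000 nM in this assay, with a range from 3000 nM to 22000 nM.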

Compound 4, half-maximal inhibitory concentration: > 20000 nM
Compound 4 was reported as a limit; the forecaster's own chance of this, stated with the estimate: 20%; at least 2.5-fold (0.39 log units) between middle value and limit.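

Going by these compounds alone, this is the first comparison in the set in which the 3,4-dihydroxyphenoxy group can be read on its own, since compounds 2 and 3 differ from compound 1 in more than one place. In this assay, 3,4-dihydroxyphenyl in place of benzyl on an oxygen on an aromatic ring gives an at least 4.2-fold higher number from compound 1 to compound 4 (0.62 log units; beyond the scatter), so at this position the change weakens inhibition rather than leaving it within the scatter. The result for compound 4 is a limit and not a number, so the step has a lower bound only, and that limit is shared: the limit of > 20000 nM in this assay, at which 2 of the 4 values shown sit.

From the compounds shown here alone, how far the weakening extends therefore stays open. Also open, going by these compounds, is how a single hydroxyl, a pair of methoxy groups or an amine on that ring would read at the same position.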